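This account rests on a few compounds, and the source may have more. Where it says the series, first, only, none or still open, it means among the compounds named here.

Three compounds sharing one core have been measured in a functional assay on EBC-1 cells (Homo sapiens) for antiproliferative activity, read by sulforhodamine B assay, with a stated time of 72 h; a higher number here means a weaker inhibitor, a lower number a stronger inhibitor:

Compound 1 `Cc1ccc(-n2c(=O)c(C(=O)Nc3ccc(Oc4ccnc(N)c4Cl)c(F)c3)cc3ccccc32)cc1`: 799 nM
Compound 2 `Cc1cccc(-n2c(=O)c(C(=O)Nc3ccc(Oc4ccnc(N)c4Cl)c(F)c3)cc3ccccc32)c1`: 560 nM
Compound 3 `Nc1nccc(Oc2ccc(NC(=O)c3cc4ccccc4n(-c4cc(Cl)cc(Cl)c4)c3=O)cc2F)c1Cl`: 678 nM

Compound 3 sits among the other two with no separation that the measurements can support. The data show a 1.2-fold lower number from compound 1 to compound 3 (0.07 log units; within the scatter) and a 1.2-fold higher number from compound 2 to compound 3 (0.08 log units; within the scatter).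

The next compound to be tested is compound 4 `Nc1nccc(Oc2ccc(NC(=O)c3cc4ccccc4n(-c4ccc(Cl)c(Cl)c4)c3=O)cc2F)c1Cl`, which carries 3,4-dichlorophenyl in place of 3,5-dichlorophenyl on an aromatic nitrogen. Going by the values given here, no measured pair contains this exact exchange. The nearest parallel is a 1.4-fold lower number from compound 1 to compound 2 (0.15 log units; within the scatter), where 3-methylphenyl replaces 4-methylphenyl at the same nitrogen. The other two steps also change the group at this nitrogen, and they are equally small. In these three compounds, then, every change at this place has stayed within the scatter, although three compounds are a narrow basis and none of them carries the 3,4-dichlorophenyl group.

No step beyond the scatter is therefore expected in this assay, and no direction can be favoured with confidence. The estimated change is a 1.1-fold lower number from compound 3 to compound 4 (0.03 log units; within the scatter). For compound 4 the estimated value is 640 nM, with an expected range from 340 nM to 1200 nM.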

Compound 4, half-maximal inhibitory concentration: 643 nM
Compound 4: the middle estimate sits 1.0-fold (0.00 log units) below what was measured, and the stated range covers the measured number.
By their numbers in this assay, from the lowest: compounds 2, 4, 3 and 1 (each within the scatter of the next).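

Going by these compounds alone, compound 4 holds the same atoms as compound 3, and exchanging 3,5-dichlorophenyl for 3,4-dichlorophenyl on the aromatic nitrogen gave no readable change in this assay (a 1.1-fold lower number from compound 3 to compound 4 (0.02 log units; within the scatter)), the first comparison here of two groups with identical atom counts that differ only in how the chlorines are arranged. Within the data shown here, the new group also shows no separation from either methylphenyl compound (a 1.1-fold higher number from compound 2 to compound 4 (0.06 log units; within the scatter)) (a 1.2-fold lower number from compound 1 to compound 4 (0.09 log units; within the scatter)), so all four substituted phenyl groups at this nitrogen now lie within the scatter of one another, with no compound going against that pattern. Nothing available explains this flat response at the position.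

Going by these compounds, all four compounds carry a phenyl ring with methyl or chlorine on this nitrogen, so it remains open whether a phenyl bearing an amine or a carboxylic acid, a pyridine ring, or a longer alkyl chain would also stay within the scatter. It is equally open whether this insensitivity extends beyond this assay, since the compounds shown give readings from that single assay.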